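The compounds below may be only part of what the source reports. "The series", "measured", "known", "first", "only" and "open" are said of these compounds alone.

Measured so far:
- compound 1, `Cc1cc(Cl)ccc1CC(C)C(=O)N1CCN(c2ccc(C(F)(F)F)cc2[C@@H](N)CC(C)C)CC1`, in an assay on HEK293 cells for displacement of a labelled ligand from Melanocortin receptor 4 (Homo sapiens); on this read-out higher numbers stand for weaker inhibition and lower numbers for stronger inhibition: 38 nM
- compound 2, `CC(C)C[C@H](N)c1cc(C(F)(F)F)ccc1N1CCN(C(=O)CSc2ccc(Cl)cc2Cl)CC1`, in this assay: 1500 nM

Compound 2 stands at the highest of the two numbers; the nearest is compound 1, which differs by a 39-fold higher number from compound 1 to compound 2 (1.60 log units; beyond the scatter). That step exchanged the whole group on the carbonyl carbon and was large, so the acyl side chain clearly matters on this read-out.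

Compound 3, `CC(C)C[C@H](N)c1cc(C(F)(F)F)ccc1N1CCN(C(=O)COc2ccc([N+](=O)[O-])cc2)CC1`, is not yet measured. It changes the same side chain once more: 4-nitrophenoxy in place of (2,4-dichlorophenyl)sulfanyl on a saturated chain carbon bound to a carbonyl carbon. Among the measured compounds shown here, the only step that bears on it is the one from compound 1 to compound 2, which was large; no measured pair shows what a nitrophenoxy group does in this place, and no pair shows an oxygen in place of the sulfur. Compound 3 is therefore expected to stay near compound 2, with a wide margin in either direction: the step of a 1.3-fold lower number from compound 2 to compound 3 (0.10 log units; within the scatter) is the expected one. Compound 3 is estimated at 1200 nM, between 200 nM and 8000 nM.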

Compound 3, inhibition constant: 3100 nM
Compound 3: the middle estimate sits 2.6-fold (0.41 log units) below what was measured; measured number inside the range.
By their numbers in this assay, from the lowest: compound 1; then compound 2; then compound 3.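

In this assay, the exchange on the saturated chain carbon bound to a carbonyl carbon gives a 2.1-fold higher number from compound 2 to compound 3 (0.32 log units; beyond the scatter), a modest step, so this place still responds to a change between two aromatic groups of similar size, one with sulfur and chlorine atoms and the other with oxygen and a nitro group. Set against the branched side chain, the (4-nitrophenoxy)methyl group gives an 82-fold higher number from compound 1 to compound 3 (1.91 log units; beyond the scatter), a large step, so both side chains with an aromatic ring held through a single sulfur or oxygen atom stand far above compound 1, and neither goes against this among the three compounds shown. Nothing at hand measures any property of these groups or explains the difference between them.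

As far as these compounds go, the step from compound 2 to compound 3 changes the linking atom and the ring substituents together, so the share of each stays open; a dichlorophenoxy group in this place would separate them. From the compounds shown here alone, it also remains open whether the carbon chain of compound 1 or its 4-chloro-2-methylbenzyl ring carries the lower number, which a plain benzyl group on the same carbonyl carbon could begin to address.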